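Solubility notes: aryl exchange on the shared core

The source may hold more compounds than are shown below. What is called first, only, known or untested is meant among the compounds shown, and "the series" means these compounds.

Compound 3 `Cc1oc(-c2c(Cl)cccc2Br)nc1CN1CCC(C(=O)NCCCN2C[C@H](C)C[C@H](C)C2)CC1` stands at a limit in a physicochemical assay for solubility, in phosphate buffer, measured as kinetic solubility, at pH 7.4; a higher number here means a more soluble compound, a lower number a less soluble compound: its reading of > 83 ug/mL is a limit of the assay, not a number. Compound 1 `Cc1ccccc1-c1nc(CN2CCC(C(=O)NCCCN3[C@H](C)CCC[C@@H]3C)CC2)c(C)o1` likewise gives a limit, > 69 ug/mL, in this assay. Compound 2 `Cc1ccccc1-c1nc(CN2CCC(C(=O)NCCCN3CCCC(C(C)C)C3)CC2)c(C)o1` also gives a limit, > 71 ug/mL. For the measured compounds named here, the one step between compounds differing in one place, a step that the two limits leave unreadable from compound 1 to compound 2, is therefore unreadable, and it concerns another part of the molecule. Compound 4 `Cc1ccc(-c2nc(CN3CCC(C(=O)NCCCN4C[C@H](C)C[C@H](C)C4)CC3)c(C)o2)cc1C` carries 3,4-dimethylphenyl in place of 2-bromo-6-chlorophenyl on an aromatic carbon. Going by the values given here, no measured step bears on this change, so no direction can be read; the three readings (the limit of > 69 ug/mL in this assay, at which 1 of the 3 values shown sits), the limit of > 71 ug/mL in this assay, at which 1 of the 3 values shown sits, and the limit of > 83 ug/mL in this assay, at which 1 of the 3 values shown sits, show only that every value so far is a limit. Compound 4 is expected to give 90 ug/mL, with a range from 35 ug/mL to 230 ug/mL. The expected step is a step that the limit leaves unreadable from compound 3 to compound 4, that is, none beyond the scatter.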

Compound 4, solubility: > 71 ug/mL
Compound 4 ended at the assay's limit (the forecaster's own chance of this, stated with the estimate: 60%); the middle value does not contradict the limit.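

Compound 3 reads > 83 ug/mL, a limit and not a number. Compound 4 reads > 71 ug/mL, also a limit, so no step can be read between the two compounds. From the compounds shown here alone, whether 3,4-dimethylphenyl in place of 2-bromo-6-chlorophenyl shifts the reading in this assay stays open.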